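The source may hold more compounds than are shown below. What is called first, only, known or untested is meant among the compounds shown, and "the series" means these compounds.

Working notes on the series.

Compound 1 `COc1cc(Cn2cc(CNC(=O)c3cn(-c4ccccc4)nc3-c3ccccc3)nn2)cc(OC)c1` is the parent of the set. In a functional assay on HeLa cells (Homo sapiens) for antiproliferative activity, read by sulforhodamine B assay, with a stated time of 48 h (on this read-out higher numbers stand for weaker inhibition of growth and lower numbers for stronger inhibition of growth), compound 1 gives 12200 nM. Compound 2 `COc1cc(Cn2cc(CNC(=O)c3cn(-c4ccccc4)nc3-c3ccccc3)nn2)cc(OC)c1OC` carries one further change, (methoxy in place of hydrogen on an aromatic carbon). For compound 2 this assay reports only a limit, > 100000 nM; this is the point (the limit of > 100000 nM in this assay, at which 1 of the 3 values shown sits). The step of an at least 8.1-fold higher number from compound 1 to compound 2 (0.91 log units; beyond the scatter) is therefore known only as a lower bound on how much weaker compound 2 is. Compound 3 `COc1cc(Cn2cc(CNC(=O)c3cn(-c4ccccc4)nc3-c3ccc(Cl)cc3)nn2)cc(OC)c1` differs from compound 1 at another place, (chloro in place of hydrogen on an aromatic carbon), and in this assay compound 3 gives 730 nM, which is the step of a 17-fold lower number from compound 1 to compound 3 (1.22 log units; beyond the scatter). Compound 3 thus stands lowest of the two numbers recorded here.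

Compound 4 `COc1cc(Cn2cc(CNC(=O)c3cn(-c4ccccc4)nc3-c3ccc(Cl)cc3)nn2)cc(OC)c1OC` has not yet been measured. It differs from compound 3 by methoxy in place of hydrogen on an aromatic carbon, the same change as that from compound 1 to compound 2, at the same place on the same ring, and the two cores differ as told by chloro in place of hydrogen on an aromatic carbon. The same change has one instance on record, an at least 8.1-fold higher number from compound 1 to compound 2 (0.91 log units; beyond the scatter), which pushed the number out to a limit. The step in this assay that the estimate means is expected to resemble that instance and is estimated at a 14-fold higher number from compound 3 to compound 4 (1.14 log units; beyond the scatter). The estimate rests on that single pair alone. Compound 4 is accordingly expected to give about 10000 nM in this assay, plausibly between 3000 nM and 60000 nM.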

Compound 4, concentration for 50% growth inhibition: 100 nM
Compound 4: middle estimate off by 100-fold (2.00 log units), on the high side; the measured number lies below the stated range.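

The step from 3,5-dimethoxyphenyl to 3,4,5-trimethoxyphenyl on the core of compound 3 is a 7.3-fold lower number from compound 3 to compound 4 (0.86 log units; beyond the scatter) in this assay, so the change does not carry over from the core of compound 1 with the same direction or size: the same change on two cores in this assay, an at least 8.1-fold higher number (0.91 log units; beyond the scatter) from compound 1 to compound 2 and a 7.3-fold lower number (0.86 log units; beyond the scatter) from compound 3 to compound 4, at least 59-fold (1.77 log units) apart, beyond the scatter of two such steps. Read the other way, chloro in place of hydrogen on an aromatic carbon gives an at least 1000-fold lower number from compound 2 to compound 4 (3.00 log units; beyond the scatter), and although the number falls on both cores, the two steps are not of the same size: the same change on two cores in this assay, a 17-fold lower number (1.22 log units; beyond the scatter) from compound 1 to compound 3 and an at least 1000-fold lower number (3.00 log units; beyond the scatter) from compound 2 to compound 4, at least 59-fold (1.77 log units) apart, beyond the scatter of two such steps. Compound 2 stands at a limit of the assay, > 100000 nM, rather than at a number, so the gap between the steps is only a lower bound, and a single pair on each core does not show whether this reversal extends beyond these four compounds: the limit of > 100000 nM in this assay, at which 1 of the 4 values shown sits.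

The compounds shown leave open whether the reversal depends on chloro itself or would also appear with fluoro, bromo or methyl in its place. They also leave open how an ethoxy in place of the added methoxy would behave on either core.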